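This account rests on a few compounds, and the source may have more. Where it says the series, first, only, none or still open, it means among the compounds named here.

Measured in an ADME assay on HEK293 cells (Homo sapiens) for cytotoxicity, read by resazurin assay, with a stated time of 48 h; a higher number here means that more compound is tolerated, a lower number that less compound is tolerated:
- compound 1, `O=S(=O)(Nc1ccc2oc(-c3ccccc3)nc2c1)c1ccc(O)cc1`: > 100000 nM, a limit of the assay
- compound 2, `COc1cccc(S(=O)(=O)Nc2ccc3oc(-c4ccccc4)nc3c2)c1`: 63000 nM
- compound 3, `CS(=O)(=O)Nc1ccc2oc(-c3ccccc3)nc2c1`: > 100000 nM, a limit of the assay

Compound 3 stands at the limit of this assay, so no number is known for it. Compound 1 sits at the same limit, and two of the three values shown are limits (the limit of > 100000 nM in this assay, at which 2 of the 3 values shown sit). Only compound 2 carries a number, and it is the lowest value in the set. For the measured compounds named here, the one readable step is an at least 1.5-fold higher number from compound 2 to compound 3 (0.20 log units; that floor lies within the scatter), with its floor inside the scatter. The step that the two limits leave unreadable from compound 1 to compound 3 cannot be read, since both ends are limits.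

Compound 4 is `O=S(=O)(Nc1ccc2oc(-c3ccccc3)nc2c1)c1cccc(O)c1`. Against compound 3 the change is 3-hydroxyphenyl in place of methyl on a sulfonyl sulfur. The measured steps that bear on it both concern an aryl group in place of methyl on the sulfonyl sulfur: one is the reverse of an at least 1.5-fold higher number from compound 2 to compound 3 (0.20 log units; that floor lies within the scatter), the other is the unreadable a step that the two limits leave unreadable from compound 1 to compound 3. Taken together, the aryl compounds sit near or at the limit, and compound 2 is only modestly below it. The expected step is therefore a small lowering at most, likely within the scatter, with a fair chance that compound 4 again reports only a limit.

For compound 4 the estimate in this assay is 90000 nM, with a range of 40000 nM to 200000 nM. That estimate means an expected step of an at least 1.1-fold lower number from compound 3 to compound 4 (0.04 log units; that floor lies within the scatter).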

Compound 4, half-maximal cytotoxic concentration: > 100000 nM
Compound 4 was reported as a limit; the forecaster's own chance of this, stated with the estimate: 55%; at least 1.1-fold (0.04 log units) between middle value and limit.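

For the compounds shown here, with 3-hydroxyphenyl on the sulfonyl sulfur, compound 4 also sits at the limit of this assay, so an aryl group at this place does not in itself give a readable number, and compound 2, with its 3-methoxyphenyl group, remains the only one of the four compounds that carries a number. Hydrogen in place of methyl on the aromatic oxygen gives an at least 1.5-fold higher number from compound 2 to compound 4 (0.20 log units; that floor lies within the scatter); this is the only readable new step, and with its floor inside the scatter it does not establish that this change matters. The other two new steps, from compound 3 and from compound 1 to compound 4, cannot be read because both ends of each are limits: the limit of > 100000 nM in this assay, at which 3 of the 4 values shown sit.

On these data alone, how far compound 1, compound 3 and compound 4 each lie beyond the limit remains unknown, so no order among them can be given. Also open, as far as these compounds go, is whether an amine or a carboxylic acid in place of the hydroxyl group, or a longer chain in place of methyl on the sulfonyl sulfur, would bring the value into the readable range of this assay.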